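A few compounds are considered here, and "the series" means these few. Any claim that something is new, unique, unknown or untested is made for them only; others in the source may bear on it.

Measured compounds:

Compound 1, `Cc1cc(C)c(NC(=O)c2sccc2S(=O)(=O)Nc2onc(C)c2Cl)c(C)c1CO`: 5110 nM
Compound 2, `CC(=O)OCc1c(C)cc(C)c(NC(=O)c2sccc2S(=O)(=O)Nc2onc(C)c2Cl)c1C`: 7420 nM
Compound 3, `Cc1cc(C)c(OC2CC2)c(C)c1NC(=O)c1sccc1S(=O)(=O)Nc1onc(C)c1Cl`: 12300 nM

These three compounds share a core and differ only in the group on one aromatic carbon. In an in vivo ADME assay on the whole organism (plasma) for pharmacokinetics, with Rattus norvegicus as the target, at a dose of 50 mg/kg by the oral route (a higher number here means more compound in the circulation at the dose given, a lower number less compound in the circulation), compound 2 gives 7420 nM, the second highest of the three numbers; its neighbours are a 1.5-fold higher number from compound 1 to compound 2 (0.16 log units; within the scatter) and a 1.7-fold higher number from compound 2 to compound 3 (0.22 log units; within the scatter), both within the scatter, while the step of a 2.4-fold higher number from compound 1 to compound 3 (0.38 log units; beyond the scatter) is modest and beyond it. The three numbers thus sit close together.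

Compound 4, `Cc1cc(C)c(S(N)(=O)=O)c(C)c1NC(=O)c1sccc1S(=O)(=O)Nc1onc(C)c1Cl`, has not yet been measured in this assay. It differs from compound 2 in one place: sulfamoyl in place of acetoxymethyl on an aromatic carbon. For the measured compounds named here, no measured step introduces a sulfamoyl group, so the bearing of the known steps is indirect: exchanges at this aromatic carbon have so far moved the number little, as a 1.5-fold higher number from compound 1 to compound 2 (0.16 log units; within the scatter) and a 1.7-fold higher number from compound 2 to compound 3 (0.22 log units; within the scatter) show. On that basis the step of a 1.2-fold lower number from compound 2 to compound 4 (0.09 log units; within the scatter) is expected to stay within the scatter, with no clear direction. Compound 4 is therefore estimated at 6000 nM, with a range from 2000 nM to 18000 nM.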

Compound 4, maximal plasma concentration: 5590 nM
Beside the measured number, compound 4's estimate is 1.1-fold (0.03 log units) above it; low and high end bracket the measured number.
By their numbers in this assay, from the lowest: compounds 1, 4, 2 and 3 (each within the scatter of the next, the first and the last beyond it).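

In this assay, for the compounds shown here, sulfamoyl, the first group here on this aromatic carbon to hold nitrogen and sulfur, stays close to the two oxygen-bearing chains: a 1.3-fold lower number from compound 2 to compound 4 (0.12 log units; within the scatter) and a 1.1-fold higher number from compound 1 to compound 4 (0.04 log units; within the scatter) are both within the scatter. Only the comparison with cyclopropyloxy goes further, with a 2.2-fold lower number from compound 3 to compound 4 (0.34 log units; beyond the scatter), a modest step beyond the scatter, although compound 3 itself remains within the scatter of compound 2. Nothing available bears on the reason for this result.

As far as these compounds go, what a carboxylic acid, a primary amine or a longer alkyl chain would do on this aromatic carbon remains open. From the compounds shown here alone, it is also open whether a sulfamoyl group with a methyl on its nitrogen would give a number close to that of compound 4.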